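The compounds below may be only part of what the source reports. "The series", "measured", "known", "first", "only" and "open" are said of these compounds alone.

Measured in an ADME assay on cells (Hepatocyte, Mus musculus) for metabolic stability, with a stated time of 30 min; a lower number here means that less of the compound is left, a higher number that more of the compound is left:
Compound 1 `NC1CCC(CN2CCN(c3cc(=O)c4cc(C(F)(F)F)cc([N+](=O)[O-])c4s3)CC2)CC1`: 107%
Compound 2 `CS(=O)(=O)NC1CCC(CN2CCN(c3cc(=O)c4cc(C(F)(F)F)cc([N+](=O)[O-])c4s3)CC2)CC1`: 111%
Compound 3 `O=c1cc(N2CCN(CC3CCCCC3)CC2)sc2c([N+](=O)[O-])cc(C(F)(F)F)cc12`: 80.6%

Compound 3, with its plain cyclohexylmethyl group, stands lowest of these three, and its gaps to both others lie beyond the usual scatter. Compound 4 `CC(=O)NC1CCC(CN2CCN(c3cc(=O)c4cc(C(F)(F)F)cc([N+](=O)[O-])c4s3)CC2)CC1` starts from compound 3 and makes one change: acetamido in place of hydrogen on a saturated ring carbon. In words, acetamido takes the place of hydrogen on a saturated ring carbon, three ring bonds from the ring atom that bears a large group.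

Two measured steps show the same kind of swap running the other way, with a group leaving that ring carbon and hydrogen taking its place. With amino leaving, the result is a number 26.4 percentage points lower from compound 1 to compound 3 (beyond the scatter), a modest step. With methanesulfonamido leaving, it is a number 30.4 percentage points lower from compound 2 to compound 3 (beyond the scatter), a large step. The two groups themselves hardly separate: a number 4 percentage points higher from compound 1 to compound 2 (within the scatter). Acetamido is a third group at this place, and it has not yet been tested. Compound 4 is therefore expected to sit with compound 1 at 107% and compound 2 at 111%, a sizeable rise over compound 3.

The expected step is a number 23.4 percentage points higher from compound 3 to compound 4 (beyond the scatter). For compound 4 the estimated value is 104%, with an expected range from 90% to 118%.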

Compound 4, percent of the compound remaining: 94.9%
Compound 4: middle estimate off by 9.1 percentage points, on the high side, within the range that was stated.
By their numbers in this assay, from the lowest: compound 3; then compound 4; then compounds 1 and 2 (each within the scatter of the next).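

In this assay, acetamido on this saturated ring carbon also leaves more of the compound than hydrogen does (a number 14.3 percentage points higher from compound 3 to compound 4 (beyond the scatter)), so a third group at this place gives a rise over the plain cyclohexylmethyl compound. The earlier compounds shown here could suggest that the group's identity hardly matters here, as amino and methanesulfonamido stayed within the scatter of each other, but acetyl on the same amine nitrogen separates from both hydrogen (a number 12.1 percentage points lower from compound 1 to compound 4 (beyond the scatter)) and methylsulfonyl (a number 16.1 percentage points lower from compound 2 to compound 4 (beyond the scatter)). What sits on that nitrogen therefore changes the result, and nothing available here accounts for the acetyl group's intermediate place.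

As far as these compounds go, it remains open whether a hydroxyl group or a carboxylic acid on this ring carbon would raise the number as far as amino and methanesulfonamido do, or only as far as acetamido. Also open, from the compounds shown here alone, is whether a longer acyl chain on the amine nitrogen, such as propanoyl, would stay with compound 4 or move towards compound 1 and compound 2.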